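The source may report more compounds than this note shows. Statements on the series, on what has been measured and on what is new or still open speak of the compounds shown alone.

Measured compounds in a functional assay on HCT-116 cells (Homo sapiens) for cytotoxicity, read by MTT assay, with a stated time of 72 h; a lower number here means a stronger inhibitor, a higher number a weaker inhibitor:
compound 1, `COc1ccc(/C=N/c2c(C)n(C)n(-c3ccccc3)c2=O)cc1OC`, gives 575000000 nM;
compound 2, `COc1ccccc1/C=N/c1c(C)n(C)n(-c2ccccc2)c1=O`, gives 324000000 nM;
compound 3, `Cc1c(/N=C/c2ccccc2)c(=O)n(-c2ccccc2)n1C`, gives 589000000 nM.

All three numbers are very high, and they lie close together. From compound 3 to compound 2 the change is methoxy in place of hydrogen on an aromatic carbon, and the step is a 1.8-fold lower number from compound 3 to compound 2 (0.26 log units; within the scatter), so the two values cannot be told apart. Compound 1 and compound 3 differ by more than one change, and the difference between the two cores is not broken down here; their values in this assay are within the scatter of each other, as are those of compound 1 and compound 2.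

The unmeasured compound 4, `COc1cc(/C=N/c2c(C)n(C)n(-c3ccccc3)c2=O)cc(OC)c1OC`, is reached from compound 1 by methoxy in place of hydrogen on an aromatic carbon. Among the compounds with values here, this is the same kind of change as the one from compound 3 to compound 2, but the surroundings differ: in compound 4 the entering methoxy sits ortho to a methoxy group, meta to a large group and meta to a methoxy group, whereas in compound 2 it sits ortho to a large group. Because the earlier step was a 1.8-fold lower number from compound 3 to compound 2 (0.26 log units; within the scatter), the expected step from compound 1 to compound 4 is a 1.3-fold lower number from compound 1 to compound 4 (0.11 log units; within the scatter), also within the scatter. Compound 4 is therefore estimated at 450000000 nM, with a likely range from 150000000 nM to 1500000000 nM.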

Compound 4, half-maximal inhibitory concentration: 525000000 nM
The estimate for compound 4 lay 1.2-fold (0.07 log units) below the measured number; the measured number falls inside the stated range.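

In this assay, methoxy in place of hydrogen on an aromatic carbon gives a 1.1-fold lower number from compound 1 to compound 4 (0.04 log units; within the scatter), and set beside the earlier step, the same change on the two cores cannot be told apart: the same change on two cores in this assay, a 1.8-fold lower number (0.26 log units; within the scatter) from compound 3 to compound 2 and a 1.1-fold lower number (0.04 log units; within the scatter) from compound 1 to compound 4, 1.7-fold (0.22 log units) apart, within the scatter of two such steps

So, for these two pairs, the change behaves alike on both cores, including in compound 4, where the entering methoxy sits ortho to a methoxy group and meta to another. This agreement is only between two steps that are both too small to read: it does not show that methoxy moves the number at all, nor that a step large enough to read would carry from one core to another.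

The compounds shown carry only hydrogen or methoxy on the six-membered aromatic ring of carbon only, so it remains open whether a hydroxyl group, an amine or a carboxylic acid there would give a step beyond the scatter. Going by these compounds, it is also open whether any such step would hold on a second core.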